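Swapping a tolyl for an indazolyl on the benzylic position

The source may report more compounds than this note shows. Statements on the series, on what has been measured and on what is new or still open speak of the compounds shown alone.

Measured compounds and their values:
- Compound 1 `CNC(=O)c1cc(C(=O)NCCCC2CNCCO2)cn(Cc2ccccc2)c1=O`: in a physicochemical assay for lipophilicity, at pH 7.4 (on this read-out higher numbers stand for higher lipophilicity and lower numbers for lower lipophilicity), compound 1 gives 1.4.
- Compound 2 `CNC(=O)c1cc(C(=O)NC2CC2)cn(Cc2ccc(C)cc2)c1=O`: in this assay compound 2 gives 3.5.
- Compound 3 `CNC(=O)c1cccn(Cc2ccccc2)c1=O`: in this assay compound 3 gives 3.

Compound 2 stands highest of the three in this assay. Its nearest neighbour is compound 3, whose value is lower by a margin beyond the scatter, and compound 1 lies further below it, again beyond the scatter.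

Compound 4 `CNC(=O)c1cc(C(=O)NC2CC2)cn(Cc2cccc3[nH]ncc23)c1=O` is not yet measured. It differs from compound 2 in one place: 1H-indazol-4-yl in place of 4-methylphenyl on a saturated chain carbon bound to an aromatic nitrogen. Going by the values given here, no pair of measured compounds differs in only this way, so the size of the step must be guessed. The entering group brings a hydrogen-bond donor and acceptor that the leaving group lacks, and the expected step from compound 2 to compound 4 in this assay is a moderate drop, a number 1.10 log units lower from compound 2 to compound 4 (beyond the scatter), beyond the scatter. Compound 4 is therefore estimated at 2.4, within a range from 1.7 to 3.1.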

Compound 4, distribution coefficient: 1.5
Compound 4: the middle estimate sits 0.90 log units above what was measured; the measured number lies below the stated range.
By their numbers in this assay, from the lowest: compounds 1 and 4 (each within the scatter of the next); then compound 3; then compound 2.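

In this assay, 1H-indazol-4-yl in place of 4-methylphenyl on a saturated chain carbon bound to an aromatic nitrogen gives a number 2.00 log units lower from compound 2 to compound 4 (beyond the scatter), a large step. The earlier compounds shown here never isolated this position, and this pair shows that exchanging one uncharged aromatic group for another here can shift the read-out strongly. Nothing available accounts for the size of this step.

As far as these compounds go, whether a naphthyl group, which has two rings of carbon only, would bring a similar step remains open. So does whether an indol-4-yl group, with a single ring nitrogen, would fall closer to 4-methylphenyl or to 1H-indazol-4-yl.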